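Furyl ketone in place of methoxyphenyl ketone

The compounds below may be only part of what the source reports. "The series", "measured", "known", "first", "only" and "open" are said of these compounds alone.

Compound 1 `COc1cc(-c2nnc3n2NC(c2ccco2)C(C(=O)c2ccccc2C)S3)cc(OC)c1OC`: 88400 nM
Compound 2 `COc1cc(-c2nnc3n2NC(c2ccco2)C(C(=O)c2cccc(Br)c2)S3)cc(OC)c1OC`: 63900 nM
Compound 3 `COc1cccc(C(=O)C2Sc3nnc(-c4cc(OC)c(OC)c(OC)c4)n3NC2c2ccco2)c1`: 84600 nM

In a functional assay on PC-3 cells (Homo sapiens) for cytotoxicity, read by MTT assay, with a stated time of 48 h (a lower number here means a stronger inhibitor, a higher number a weaker inhibitor), all three measured compounds give weak numbers of similar size. Compound 3 stands second highest of the three; the nearest is compound 1, with a 1.0-fold lower number from compound 1 to compound 3 (0.02 log units; within the scatter), and the furthest is compound 2, with a 1.3-fold higher number from compound 2 to compound 3 (0.12 log units; within the scatter). Both gaps lie within the scatter, so no order among them can be read.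

Compound 4 `COc1cc(-c2nnc3n2NC(c2ccco2)C(C(=O)c2ccco2)S3)cc(OC)c1OC` differs from compound 3 by furan-2-yl in place of 3-methoxyphenyl on a carbonyl carbon. The steps measured so far all exchange the group on the carbonyl carbon: a 1.4-fold lower number from compound 1 to compound 2 (0.14 log units; within the scatter), a 1.0-fold lower number from compound 1 to compound 3 (0.02 log units; within the scatter) and a 1.3-fold higher number from compound 2 to compound 3 (0.12 log units; within the scatter), each within the scatter. None of them introduces a five-membered aromatic ring, so the move to furan-2-yl is not directly covered; what the measured steps show is that changes at this carbonyl carbon have left the number essentially unmoved.

Compound 4 is therefore expected to show no step beyond the scatter, a 1.1-fold lower number from compound 3 to compound 4 (0.02 log units; within the scatter). The estimate for compound 4 is 80000 nM, with a range from 35000 nM to 180000 nM.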

Compound 4, half-maximal inhibitory concentration: 58300 nM
The estimate for compound 4 lay 1.4-fold (0.14 log units) above the measured number; the measured number falls inside the stated range.
By their numbers in this assay, from the lowest: compounds 4, 2, 3 and 1 (each within the scatter of the next).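

In this assay a five-membered aromatic ring on the carbonyl carbon joins the six-membered aromatic rings already seen there, and the number stays within the scatter of all three: (a 1.5-fold lower number from compound 3 to compound 4 (0.16 log units; within the scatter)), (a 1.1-fold lower number from compound 2 to compound 4 (0.04 log units; within the scatter)) and (a 1.5-fold lower number from compound 1 to compound 4 (0.18 log units; within the scatter)). Going from 3-methoxyphenyl, with 8 heavy atoms, to furan-2-yl, with 5, thus leaves the number as unmoved as the exchanges among substituted phenyl groups did, so neither the ring size nor the ring type tested here separates these compounds. Nothing measured here bears on why the number stays put.

From the compounds shown here alone, all four compounds carry an aromatic ring on this carbonyl carbon, so it remains open whether a saturated amine such as piperidine, or a phenyl ring bearing a carboxylic acid, would move the number beyond the scatter. Also open, going by these compounds, is whether any change outside this carbonyl group matters: the rest of the structure is the same in all four.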